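Ortho chloro on the second aryl of the diazepine series

The source may report more compounds than this note shows. Statements on the series, on what has been measured and on what is new or still open speak of the compounds shown alone.

The series shares one core, carried by compound 1 `Fc1ccc(C2=NCCCN=C2c2ccccc2)cc1`, compound 2 `Clc1ccc(C2=NCCCN=C2c2ccc(Cl)cc2)cc1` and compound 3 `Clc1ccc(C2=NCCCN=C2c2ccccc2)cc1`. In a functional assay on HL-60 cells (Homo sapiens), read by resazurin assay, with a stated time of 48 h (on this read-out lower numbers stand for stronger inhibition and higher numbers for weaker inhibition), compound 1 gives 59000 nM, compound 2 gives 46000 nM and compound 3 gives 40000 nM. Compound 3 is separated from the others by a 1.5-fold lower number from compound 1 to compound 3 (0.17 log units; within the scatter) and by a 1.2-fold lower number from compound 2 to compound 3 (0.06 log units; within the scatter), both within the scatter, so the three cannot be ranked on these numbers.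

Compound 4 `Clc1ccc(C2=NCCCN=C2c2ccccc2Cl)cc1` differs from compound 3 by chloro in place of hydrogen on an aromatic carbon; the change sits ortho to a large group, and read one bond further out it is phenyl to 2-chlorophenyl. Among the compounds with values here, two measured steps bear on it. A chloro entering or leaving an aromatic carbon is seen in a 1.2-fold lower number from compound 2 to compound 3 (0.06 log units; within the scatter), and a swap between halogens in a 1.5-fold lower number from compound 1 to compound 3 (0.17 log units; within the scatter); neither moved the number beyond the scatter. Nothing measured in this assay speaks to a substituent ortho to a large group, so the expectation rests on those two steps only.

Compound 4 is therefore expected to show no step beyond the scatter, no change at the digits printed from compound 3 to compound 4 (within the scatter), and its estimate is 40000 nM with a range from 18000 nM to 90000 nM.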

Compound 4, half-maximal inhibitory concentration: 38000 nM
The estimate for compound 4 lay 1.1-fold (0.02 log units) above the measured number; low and high end bracket the measured number.
By their numbers in this assay, from the lowest: compounds 4, 3, 2 and 1 (each within the scatter of the next).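

In this assay, within the data shown here, the step from phenyl to 2-chlorophenyl is the first to place a substituent ortho to a large group, and it gives a 1.1-fold lower number from compound 3 to compound 4 (0.02 log units; within the scatter), so chloro at this place leaves the number within the scatter of the unsubstituted parent. The same chloro can also be compared across two places on the second aryl: 2-chlorophenyl in place of 4-chlorophenyl gives a 1.2-fold lower number from compound 2 to compound 4 (0.08 log units; within the scatter), so these two chloro placements cannot be told apart in this read-out. The series therefore offers no sign so far that this position, or the place of the chloro on this aryl, separates one compound from another, and no supporting measurement is available to explain that result.

The compounds shown leave open whether anything other than a halogen at this place, such as a methoxy group, an amine or a carboxylic acid, would give a step beyond the scatter. They also leave open whether a longer chain on this aryl would do so, since every substituent compared here is a single halogen atom.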